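Amino-for-Hydrogen Step Carried to a Second Core

The source may report more compounds than this note shows. Statements on the series, on what has been measured and on what is new or still open speak of the compounds shown alone.

Compound 1 `ClCc1ccc(Cn2cnc3c(Cl)ncnc32)cc1` is the reference point; in a functional assay on CAKI-1 cells (Homo sapiens) for cytotoxicity, read by sulforhodamine B assay, with a stated time of 48 h (on this read-out lower numbers stand for stronger inhibition of growth and higher numbers for weaker inhibition of growth), compound 1 gives 260 nM. Compound 2 `Nc1nc(Cl)c2ncn(Cc3ccc(CCl)cc3)c2n1` carries the change (amino in place of hydrogen on an aromatic carbon); in this assay compound 2 gives 2510 nM, a step of a 9.7-fold higher number from compound 1 to compound 2 (0.98 log units; beyond the scatter). Compound 3 `ClCc1ccccc1Cn1cnc2c(Cl)ncnc21` has the same atoms as compound 1 joined differently; the difference between the two cores is not broken down here. In this assay compound 3 gives 1820 nM. Compound 4 `Nc1nc(Cl)c2ncn(Cc3ccccc3CCl)c2n1` is not yet measured and differs from compound 3 by amino in place of hydrogen on an aromatic carbon, the same change seen in the measured pair, occurring twice among these compounds, with the place described in identical words. Going by the values given here, the step to compound 4 in this assay is expected to be an 8.2-fold higher number from compound 3 to compound 4 (0.92 log units; beyond the scatter), resting on the single earlier step of a 9.7-fold higher number from compound 1 to compound 2 (0.98 log units; beyond the scatter). Compound 4 is accordingly estimated at 15000 nM, with an expected range of 5000 nM to 45000 nM.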

Compound 4, concentration for 50% growth inhibition: 6610 nM
Beside the measured number, compound 4's estimate is 2.3-fold (0.36 log units) above it; the measured number falls inside the stated range.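

In this assay amino in place of hydrogen on an aromatic carbon gives a 3.6-fold higher number from compound 3 to compound 4 (0.56 log units; beyond the scatter) on the second core, the same direction as on the first. The two steps cannot be told apart in size, so in this pair of cores the change carries over: the same change on two cores in this assay, a 9.7-fold higher number (0.98 log units; beyond the scatter) from compound 1 to compound 2 and a 3.6-fold higher number (0.56 log units; beyond the scatter) from compound 3 to compound 4, 2.7-fold (0.42 log units) apart, within the scatter of two such steps. This rests on two pairs in one cell line, and it shows neither why the number rises nor whether the step holds on any other core.

Still open, as far as these compounds go, is how a methylamino or hydroxyl group would behave in place of the amino group on either core. Also open, from the compounds shown here alone, is whether the step would persist if the chloro group were replaced by a methoxy group.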